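Thioester variation on the coumarin-like carboxamide series

This account rests on a few compounds, and the source may have more. Where it says the series, first, only, none or still open, it means among the compounds named here.

Compound 1 `CC(C)(C)NC(=O)c1cc2ccccc2oc1=O` and compound 2 `CCC(C)NC(=O)c1cc2cc(Br)cc(Br)c2oc1=O` carry amides on the shared core; compound 3 `O=C(Sc1ccc(Br)cc1)c1cc2ccccc2oc1=O` carries a thioester instead. In an assay on isolated protein for inhibition of Amine oxidase [flavin-containing] A (Homo sapiens), read by fluorescence (a higher number here means a weaker inhibitor, a lower number a stronger inhibitor), compound 3 gives 22700 nM, with compound 1 at 40400 nM and compound 2 at 42300 nM, both within the usual scatter of the number for compound 3, so no ordering among the three is supported. Compound 4 `O=C(SCc1ccco1)c1cc2ccccc2oc1=O` keeps the thioester and differs from compound 3 only in that ((furan-2-yl)methyl in place of 4-bromophenyl on a sulfur). Among the measured compounds shown here, no measured pair isolates such a change, so no step beyond the scatter is expected in either direction. Compound 4 is estimated at 25000 nM in this assay, between 8000 nM and 80000 nM, which means an expected step of a 1.1-fold higher number from compound 3 to compound 4 (0.04 log units; within the scatter).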

Compound 4, half-maximal inhibitory concentration: 39700 nM
Estimate against measurement, compound 4: 1.6-fold (0.20 log units) below; the measured number falls inside the stated range.
By their numbers in this assay, from the lowest: compounds 3, 4, 1 and 2 (each within the scatter of the next).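

In this assay, among the compounds shown here, (furan-2-yl)methyl in place of 4-bromophenyl on the sulfur gives a 1.7-fold higher number from compound 3 to compound 4 (0.24 log units; within the scatter), the only step here between compounds that differ in one place. At this position, a five-membered aromatic ring with one hetero atom and a six-membered carbon ring bearing bromine therefore cannot be told apart, and the thioester series shows no readable change. Nothing available bears on this result.

Open, as far as these compounds go, is how a thioester compares with an amide bearing the same group on the shared core, and whether a butyl chain or a benzyl group on the sulfur moves the number beyond the scatter.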